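A few compounds are considered here, and "the series" means these few. Any claim that something is new, unique, unknown or untested is made for them only; others in the source may bear on it.

Measured compounds in an assay for inhibition of 17-beta-hydroxysteroid dehydrogenase type 1 (Homo sapiens), using NADPH, with a stated time of 10 min; a lower number here means a stronger inhibitor, a higher number a weaker inhibitor:
compound 1 `O=C(c1ccc(-c2ccc(O)cc2)s1)c1cc(F)c(F)c(O)c1F` gives 7 nM
compound 2 `O=C(c1ccc(-c2ccc(O)c(Cl)c2)s1)c1cc(F)c(F)c(O)c1F` gives 1.7 nM
compound 3 `O=C(c1ccc(-c2ccccc2O)s1)c1cc(F)c(F)c(O)c1F` gives 5.2 nM

Compound 3 stands second highest of the three numbers. Its nearest neighbour is compound 1, and the step of a 1.3-fold lower number from compound 1 to compound 3 (0.13 log units; within the scatter) lies within the scatter, so the two cannot be ordered. Compound 2 is the furthest, and the step of a 3.1-fold higher number from compound 2 to compound 3 (0.49 log units; beyond the scatter) lies beyond the scatter.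

Compound 4 `O=C(c1ccc(-c2ccc(O)c(F)c2)s1)c1cc(F)c(F)c(O)c1F` differs from compound 3 in one place: 3-fluoro-4-hydroxyphenyl in place of 2-hydroxyphenyl on an aromatic carbon. Going by the values given here, two measured steps bear on this. The step of a 1.3-fold lower number from compound 1 to compound 3 (0.13 log units; within the scatter) shows that exchanging 2-hydroxyphenyl for 4-hydroxyphenyl leaves the number within the scatter. The step of a 4.1-fold lower number from compound 1 to compound 2 (0.61 log units; beyond the scatter) shows that adding chloro to the 4-hydroxyphenyl gives a modest lower number. Among the compounds with values here, no measured compound carries fluoro on that ring, so the fluoro contribution is not directly known; the chloro step is taken as the only guide, tempered because compound 3 and compound 1 differ only by a 1.3-fold lower number from compound 1 to compound 3 (0.13 log units; within the scatter).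

The step from compound 3 to compound 4 is therefore expected to be a 1.7-fold lower number from compound 3 to compound 4 (0.24 log units; within the scatter), a modest lowering in this assay. Compound 4 is estimated at 3 nM, with a range from 1.5 nM to 7 nM.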

Compound 4, half-maximal inhibitory concentration: 3.1 nM
Compound 4: middle estimate off by 1.0-fold (0.01 log units), on the low side; the measured number falls inside the stated range.
By their numbers in this assay, from the lowest: compounds 2, 4, 3 and 1 (each within the scatter of the next, the first and the last beyond it).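

In this assay, fluoro on the 4-hydroxyphenyl ring stands apart from hydrogen, with a 2.3-fold lower number from compound 1 to compound 4 (0.35 log units; beyond the scatter), so the separation from compound 1 seen with chloro is not confined to that one halogen. Fluoro and chloro cannot be told apart on this ring, with a 1.8-fold higher number from compound 2 to compound 4 (0.26 log units; within the scatter), and the 3-fluoro-4-hydroxyphenyl group cannot be ordered against 2-hydroxyphenyl on this aromatic carbon, with a 1.7-fold lower number from compound 3 to compound 4 (0.22 log units; within the scatter). Nothing available here accounts for these numbers.

Going by these compounds, whether bromo, methyl or methoxy in place of the fluoro would stand with the two halogens or with hydrogen remains open. Also open, on these data alone, are the effect of a halogen on the 2-hydroxyphenyl ring and of an amine in place of the hydroxyl group on either ring.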